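Adding Pyrrolidin-1-yl to the Phenyl Ring of Compound 1

The source may hold more compounds than are shown below. What is called first, only, known or untested is meant among the compounds shown, and "the series" means these compounds.

Compound 1 `c1ccc(NCc2ccc(CNc3ncccn3)cc2)cc1` has been measured in a functional assay on MDA-MB-231 cells for antagonist activity at C-X-C chemokine receptor type 4 (Homo sapiens), tested at 10 nM (a higher number here means a stronger effect of the compound at the concentration tested, a lower number a weaker effect), where compound 1 gives 55%, the lowest of the two numbers shown, although only by a step within the scatter. The other measured compound, compound 2 `c1ccc(NCc2ccc(CNc3ncccn3)cc2)nc1`, gives 58% in this assay, and the step of a number 3 percentage points higher from compound 1 to compound 2 (within the scatter) comes from pyridin-2-yl in place of phenyl on an amine nitrogen. Compound 3 `c1cnc(NCc2ccc(CNc3cccc(N4CCCC4)c3)cc2)nc1` differs from compound 1 by pyrrolidin-1-yl in place of hydrogen on an aromatic carbon. Among the measured compounds shown here, that single measured step alters a different part of the molecule and stays within the scatter, so no measured step bears directly on this change. With no guide, the expected step is no change at the digits printed from compound 1 to compound 3 (within the scatter), none beyond the scatter. Compound 3 is therefore estimated at 55%, between 35% and 75%.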

Compound 3, a percentage reported as inhibition, at one concentration (the size of the read-out at that concentration, not a potency): 41%
Compound 3: the middle estimate sits 14 percentage points above what was measured; measured number inside the range.
By their numbers in this assay, from the lowest: compound 3; then compounds 1 and 2 (each within the scatter of the next).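

Among the compounds shown here, the carbon ring of compound 1 had not been changed in the earlier compounds, and pyrrolidin-1-yl on this aromatic carbon, meta to a large group, gives in this assay (a number 14 percentage points lower from compound 1 to compound 3 (beyond the scatter)). So this position responds to substitution, and this is the first step shown that lies beyond the scatter. Nothing available accounts for this lower number.

From the compounds shown here alone, whether methyl, methoxy or an open-chain dimethylamino group on the same carbon would lower the number as well stays open. So does whether piperidin-1-yl or morpholin-4-yl would behave like pyrrolidin-1-yl.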